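The source may hold more compounds than are shown below. What is called first, only, known or untested is meant among the compounds shown, and "the series" means these compounds.

Measured in a functional assay on MCF7 cells (Homo sapiens) for cytotoxicity, read by MTT assay, with a stated time of 3 days; on this read-out lower numbers stand for stronger inhibition and higher numbers for weaker inhibition:
- Compound 1 `COc1ccc(-c2ccccc2)cc1OC`: 45 ug/mL
- Compound 2 `COc1ccc(-c2cccc(O)c2)cc1OC`: 48 ug/mL

Only these two numbers exist so far, and compound 2, at 48 ug/mL, cannot be told apart from compound 1, at 45 ug/mL. Compound 3 `COc1ccc(-c2cccc(N)c2)cc1OC` has amino in place of hydroxy on an aromatic carbon of compound 2 (amino in place of hydroxy on an aromatic carbon). Among the compounds with values here, the only measured step that bears on this change is a 1.1-fold higher number from compound 1 to compound 2 (0.03 log units; within the scatter), which put hydroxy in place of hydrogen on an aromatic carbon. Within the data shown here, that step stayed within the scatter, but no compound carrying amino has been measured, so the evidence is thin. No clear step in either direction is therefore expected in this assay. The expected change is a 1.1-fold lower number from compound 2 to compound 3 (0.06 log units; within the scatter). For compound 3 the estimated value is 42 ug/mL, with an expected range of 18 ug/mL to 90 ug/mL.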

Compound 3, half-maximal inhibitory concentration: > 100 ug/mL
Compound 3: a limit, no number; the forecaster's own chance of this, stated with the estimate: 10%; middle value at least 2.3-fold (0.37 log units) from the limit.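

In this assay, compound 3 gives > 100 ug/mL, which is a limit and not a number. Hydrogen and hydroxy could not be told apart at this position, but amino gives an at least 2.0-fold higher number from compound 2 to compound 3 (0.31 log units; beyond the scatter) and an at least 2.2-fold higher number from compound 1 to compound 3 (0.34 log units; beyond the scatter), so the position does respond to what it carries. This holds even though hydroxy and amino have the same counts of heavy atoms and of hydrogen-bond donors and acceptors. The size of both steps is only a lower bound because the reading for compound 3 is a limit: the limit of > 100 ug/mL in this assay, at which 1 of the 3 values shown sits.

The compounds shown leave open whether this weakening belongs to amino alone or also appears with other groups at this place, such as methoxy, an acetamide or a carboxylic acid. They also leave open how much weaker compound 3 really is.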